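The source may hold more compounds than are shown below. What is called first, only, known or untested is meant among the compounds shown, and "the series" means these compounds.

Compound 1 `CC/C=C\CC1C(=O)C=CC1CC(=O)OC` gives 140 uM in an ADME assay on RAW264.7 cells (Mus musculus) for cytotoxicity, read by MTT assay, with a stated time of 24 h; a higher number here means that more compound is tolerated, a lower number that less compound is tolerated. Compound 2 `CC/C=C\C[C@H]1C(=O)C=C[C@H]1CC(=O)OCCC` gives 35 uM. Compound 3 `CC/C=C\C[C@H]1C(=O)C=C[C@H]1CC(=O)OCCCCC` gives 37 uM.

Compound 3 holds the second highest of the three numbers. Its nearest neighbour is compound 2, whose value lies within the scatter of its own, so no order between the two can be claimed. Compound 1 lies furthest away, with a value beyond the scatter and higher than that of compound 3.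

Compound 4 `CC/C=C\C[C@H]1C(=O)C=C[C@H]1CC(=O)OCc1ccccc1` differs from compound 3 by phenyl in place of butyl on a saturated chain carbon bound to an oxygen next to a carbonyl group. Among the measured compounds shown here, the one measured step that touches the ester chain is a 1.1-fold higher number from compound 2 to compound 3 (0.02 log units; within the scatter), a change within the scatter. For the measured compounds named here, no measured step exchanges a chain for a ring, so the data give no direction for the new change. On the basis of compound 3 and the step from compound 2 to compound 3, compound 4 is expected to show a value close to that of compound 3, with a step of a 1.1-fold lower number from compound 3 to compound 4 (0.02 log units; within the scatter) that stays within the scatter. Compound 4 is estimated at 35 uM, with a range from 15 uM to 80 uM.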

Compound 4, half-maximal toxic concentration: 31 uM
Compound 4: middle estimate off by 1.1-fold (0.05 log units), on the high side; measured number inside the range.
By their numbers in this assay, from the lowest: compounds 4, 2 and 3 (each within the scatter of the next); then compound 1.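

In this assay, phenyl in place of butyl on a saturated chain carbon bound to an oxygen next to a carbonyl group gives a 1.2-fold lower number from compound 3 to compound 4 (0.08 log units; within the scatter) and phenyl in place of ethyl at the same place gives a 1.1-fold lower number from compound 2 to compound 4 (0.05 log units; within the scatter). The earlier step covered only a change in chain length, whereas these two steps show that an aromatic ring at this place also leaves the number within the scatter of both chains, so compound 2, compound 3 and compound 4 cannot be put in any order. Nothing available explains why the number stays put here.

On these data alone, it remains open whether any group at this place would move the number beyond the scatter, for instance a much longer chain, an amine or a carboxylic acid. As far as these compounds go, it is equally open whether a substituent on the phenyl ring would do so.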